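This account rests on a few compounds, and the source may have more. Where it says the series, first, only, none or still open, it means among the compounds named here.

For the measured compounds named here, compound 3, `Cc1nc(NCCC(F)(F)F)nc(N[C@@H]2C[C@H](CO)[C@@H](O)[C@H]2O)c1-c1nc2ccccc2s1`, is the only member of this small set to return a number in an ADME assay on cells (Homo sapiens) for cytotoxicity, read by polymerase chain reaction, with a stated time of 3 days; a lower number here means that less compound is tolerated, a higher number that more compound is tolerated; the two other values are limits of the assay. Compound 1, `CNc1nc(C)c(-c2nc3ccccc3s2)c(N[C@@H]2C[C@H](CO)[C@@H](O)[C@H]2O)n1`, reaches only the limit > 25000 nM in this assay. Compound 2, `Cc1nc(NCCNC(=O)NC(C)(C)C)nc(N[C@@H]2C[C@H](CO)[C@@H](O)[C@H]2O)c1-c1nc2ccccc2s1`, likewise stops at the limit > 25000 nM in this assay. Compound 3 itself gives 9000 nM in this assay. That number lies under the limit at which the other two values sit, (the limit of > 25000 nM in this assay, at which 2 of the 3 values shown sit), with an at least 2.7-fold lower number from compound 1 to compound 3 (0.44 log units; beyond the scatter) and an at least 2.7-fold lower number from compound 2 to compound 3 (0.44 log units; beyond the scatter).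

Compound 4, `Cc1nc(NCc2ccccn2)nc(N[C@@H]2C[C@H](CO)[C@@H](O)[C@H]2O)c1-c1nc2ccccc2s1`, differs from compound 3 in one place: pyridin-2-yl in place of 2,2,2-trifluoroethyl on a saturated chain carbon bound to a nitrogen on an aromatic ring. Both measured steps leading to compound 3 were downward steps into a number from a limit, and each involved a change on the saturated chain carbon bound to the ring nitrogen. Removing the 2,2,2-trifluoroethyl there is therefore expected to move compound 4 back toward the limit, with an estimated 2.0-fold higher number from compound 3 to compound 4 (0.30 log units; within the scatter). Compound 4 is expected to give about 18000 nM, within 6000 nM to 25000 nM.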

Compound 4, half-maximal cytotoxic concentration: 13000 nM
Estimate against measurement, compound 4: 1.4-fold (0.14 log units) above; measured number inside the range.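

At this saturated chain carbon bound to a nitrogen on an aromatic ring, putting pyridin-2-yl in place of 2,2,2-trifluoroethyl gives a 1.4-fold higher number from compound 3 to compound 4 (0.16 log units; within the scatter) in this assay and so leaves the reading within the scatter. For the compounds shown here, compound 3 is therefore no longer the only compound with a number, as compound 4, with an aromatic ring at this place, also gives one. The comparisons with the two other compounds read an at least 1.9-fold lower number from compound 2 to compound 4 (0.28 log units; that floor lies within the scatter) and an at least 1.9-fold lower number from compound 1 to compound 4 (0.28 log units; that floor lies within the scatter) and remain floors that do not establish a step beyond the scatter, because those two values are limits: the limit of > 25000 nM in this assay, at which 2 of the 4 values shown sit.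

Going by these compounds, whether the ring nitrogen of pyridin-2-yl plays any part remains open, and a phenyl group at this place would bear on that. Also open, on these data alone, is how a carboxylic acid or a longer chain ending in an amine would read here.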